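From tert-butyl to cyclopropyl: a small swap

This account rests on a few compounds, and the source may have more. Where it says the series, first, only, none or still open, it means among the compounds named here.

Compound 1 `O=C(NCc1cc(Cl)ccc1-n1cnnn1)[C@@H]1CCNN1C(=O)[C@H](O)c1ccccc1` gives 930 nM
Compound 2 `CC(C)(C)C[C@@H](O)C(=O)N1C[C@@H]2C[C@@H]2[C@H]1C(=O)NCc1cc(Cl)ccc1-n1cnnn1` gives 910 nM

Both numbers come from a functional assay on a cell-free system (plasma, Homo sapiens), with a stated time of 3 min (on this read-out lower numbers stand for stronger inhibition and higher numbers for weaker inhibition), and lie within the usual scatter of each other. Compound 2 therefore stands level with compound 1, although the two structures differ in more than one place.

Compound 3 `O=C(NCc1cc(Cl)ccc1-n1cnnn1)[C@@H]1[C@H]2C[C@H]2CN1C(=O)[C@H](O)CC1CC1` keeps the core of compound 2 and alters one group: cyclopropyl in place of tert-butyl on a saturated chain carbon, two bonds along the chain from a carbonyl carbon and an oxygen on a saturated carbon. The change lies on a saturated chain carbon, two bonds along the chain from a carbonyl carbon and an oxygen on a saturated carbon. Cut one bond further out, it reads neopentyl to cyclopropylmethyl.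

Among the compounds with values here, no measured pair shows what this exchange does in this assay, so the expectation simply starts from compound 2 at 910 nM and stays cautious. The expected change is a 1.4-fold higher number from compound 2 to compound 3 (0.15 log units; within the scatter), a small move toward a higher number, meaning slightly weaker inhibition, and probably no larger than the scatter. Compound 3 is estimated at 1300 nM, with an expected range from 450 nM to 3800 nM.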

Compound 3, half-maximal inhibitory concentration: 1400 nM
For compound 3 the middle estimate is 1.1-fold (0.03 log units) below the measured one, within the range that was stated.
By their numbers in this assay, from the lowest: compounds 2, 1 and 3 (each within the scatter of the next).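

In this assay the swap gives a 1.5-fold higher number from compound 2 to compound 3 (0.19 log units; within the scatter) and so, in this first pair that differs in one place, compound 2 and compound 3 cannot be told apart. The exchange removes tert-butyl, with 4 heavy atoms and no ring, and brings in cyclopropyl, with 3 heavy atoms and one three-membered non-aromatic ring, yet at this saturated chain carbon that difference does not carry the read-out beyond the usual scatter of repeated measurements. No measured evidence is at hand to say why the two groups read alike.

Both groups are made of carbon only, with 0 hydrogen-bond donors and 0 hydrogen-bond acceptors, so the compounds shown say nothing about how an amine, a carboxylic acid or a longer chain would read at this place. On these data alone, it also remains open whether the same exchange would read alike on the core of compound 1, since this single pair covers only the core shared by compound 2 and compound 3.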